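The compounds below may be only part of what the source reports. "The series", "measured", "known", "first", "only" and "open" are said of these compounds alone.

Three compounds have been measured in a functional assay on HCT-116 cells (Homo sapiens) for antiproliferative activity, read by MTT assay, with a stated time of 72 h; on this read-out lower numbers stand for stronger inhibition and higher numbers for weaker inhibition:

compound 1, `COc1cccc(N2C(=O)COc3ccc(-c4cnc(Cl)c(NS(=O)(=O)c5ccc(F)cc5)c4)cc32)c1`, > 40000 nM
compound 2, `CC(C)N1C(=O)COc2ccc(-c3cccc(NS(=O)(=O)c4ccc(F)cc4)c3)cc21`, 22600 nM
compound 3, `O=C1COc2ccc(-c3cccc(NS(=O)(=O)c4ccc(F)cc4)c3)cc2N1c1ccc(Cl)cc1`, 23900 nM

Among the compounds with values here, the value for compound 1 is a limit of this assay, not a number, so compound 1 has no exact place among the values shown; it is the one compound sitting at the limit of > 40000 nM in this assay, at which 1 of the 3 values shown sits. Compound 2 and compound 3 lie close together, as a 1.1-fold higher number from compound 2 to compound 3 (0.02 log units; within the scatter) shows, and that step concerns 4-chlorophenyl in place of isopropyl on an amide-type nitrogen in a ring.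

Compound 4, `O=C1COc2ccc(-c3cnc(Cl)c(NS(=O)(=O)c4ccc(F)cc4)c3)cc2N1c1ccccc1`, differs from compound 1 by hydrogen in place of methoxy on an aromatic carbon. Within the data shown here, no measured step touches this change; the single step measured concerns another part of the shared core. The expectation therefore rests on compound 1 alone, and little movement beyond the scatter is expected from the removal of the methoxy. Compound 4 is estimated at 45000 nM, within 15000 nM to 150000 nM. This estimate means an expected step that the limit leaves unreadable from compound 1 to compound 4.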

Compound 4, half-maximal inhibitory concentration: 39800 nM
The estimate for compound 4 lay 1.1-fold (0.05 log units) above the measured number, and the stated range covers the measured number.
By their numbers in this assay, from the lowest: compounds 2, 3 and 4 (each within the scatter of the next). At a limit, above all of these: compound 1.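

Within the data shown here, compound 4 gives the first number for a compound carrying the unsubstituted phenyl: in this assay, compound 4 stands at 39800 nM. For compound 1 the value, > 40000 nM, is a limit and not a number. The change from 3-methoxyphenyl to phenyl therefore gives a number no higher from compound 1 to compound 4 (the limit leaves the size open). Compound 1 sits at the limit: the limit of > 40000 nM in this assay, at which 1 of the 4 values shown sits.

The compounds shown leave open how other groups in place of the methoxy, such as an amine or a carboxylic acid, would read in this assay. They also leave open whether a methoxy on this ring would read differently on the core of compound 2, which carries isopropyl on the amide-type nitrogen instead.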